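The source may hold more compounds than are shown below. What is called first, only, known or untested is meant among the compounds shown, and "the series" means these compounds.

Compound 2, `C=C1[C@H](OC(C)=O)[C@@H](OC(C)=O)[C@@H](OC(C)=O)C(C)(C)/C=C/[C@H](C)[C@H](OC(=O)c2ccccc2)[C@@]2(O)C[C@@](C)(O)[C@H](OC(C)=O)[C@@H]2[C@H]1OCC(C)C`, stands in a functional assay on NCI/ADR-RES cells (Homo sapiens) for antiproliferative activity, read by MTT assay, with a stated time of 48 h (on this read-out higher numbers stand for weaker inhibition and lower numbers for stronger inhibition), only at a limit of the assay: compound 2 gives > 100000 nM. Its two measured neighbours stand in the same way. Compound 1, `C=C1[C@H](OC(C)=O)[C@@H](OC(C)=O)[C@@H](O)C(C)(C)/C=C/[C@H](C)[C@H](OC(=O)c2ccccc2)[C@@]2(O)C[C@@](C)(O)[C@H](OC(C)=O)[C@@H]2[C@H]1OCC(C)C`, carries hydrogen where compound 2 carries an acetyl on an oxygen on a saturated carbon, and in this assay compound 1 gives > 100000 nM, which is again a limit. Compound 3, `C=C1[C@H](OC(C)=O)[C@@H](OC(=O)C(C)(C)C)[C@@H](OC(C)=O)C(C)(C)/C=C/[C@H](C)[C@H](OC(=O)c2ccccc2)[C@@]2(O)C[C@@](C)(O)[C@H](OC(C)=O)[C@@H]2[C@H]1OCC(C)C`, carries tert-butyl in place of methyl on a carbonyl carbon, and compound 3 gives > 100000 nM, also a limit. The step that the two limits leave unreadable from compound 1 to compound 2 and the step that the two limits leave unreadable from compound 2 to compound 3 are therefore of unreadable size, because of the limit of > 100000 nM in this assay, at which 3 of the 3 values shown sit.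

Compound 4, `C=C1[C@H](OC(C)=O)[C@@H](OC(C)=O)[C@@H](OC(C)=O)C(C)(C)/C=C/[C@H](C)[C@H](OC(=O)c2ccccc2)[C@@]2(O)C[C@@](C)(OC(=O)c3ccncc3)[C@H](OC(C)=O)[C@@H]2[C@H]1OCC(C)C`, differs from compound 2 by (pyridin-4-yl)carbonyl in place of hydrogen on an oxygen on a saturated carbon. Neither measured step bears on this change in a readable way, and none of the three values shown is a number. The expectation for compound 4 rests on that alone: a step of a number no higher from compound 2 to compound 4 (the limit leaves the size open) is expected, most likely leaving compound 4 at the same limit as its three relatives. The estimate for compound 4 in this assay is 100000 nM, expected to fall between 20000 nM and 300000 nM.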

Compound 4, half-maximal inhibitory concentration: > 100000 nM
Compound 4 was reported as a limit; the forecaster's own chance of this, stated with the estimate: 70%; the middle value lies on the limit itself.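

In this assay compound 4 gives > 100000 nM, which is a limit and not a number. No step from compound 2 to compound 4 can therefore be read: the limit of > 100000 nM in this assay, at which 4 of the 4 values shown sit.

The compounds shown leave open how strongly compound 1, compound 2, compound 3 or compound 4 inhibits these cells, and which change to the shared core would yield a readable number.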